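The source may report more compounds than this note shows. Statements on the series, on what has been measured and on what is new or still open speak of the compounds shown alone.

Measured in a functional assay (aorta) with Oryctolagus cuniculus as the target; on this read-out lower numbers stand for stronger inhibition and higher numbers for weaker inhibition:
compound 1 `Fc1ccccc1Cn1nc(-c2ccco2)c2cccnc21` gives 9300 nM
compound 2 `Cc1nc(-c2nn(Cc3ccccc3F)c3ncccc23)oc1CO` gives 900 nM
compound 3 `CC(C)c1cnc(-c2nn(Cc3ccccc3F)c3ncccc23)nc1N` gives 207000 nM

Compound 3 stands at the highest number of the three, the weakest inhibitor in this assay. Its nearest neighbour is compound 1, which lies well below it; compound 2 lies furthest below. Compound 4 `CC(C)S(=O)(=O)c1cnc(-c2nn(Cc3ccccc3F)c3ncccc23)nc1N` differs from compound 3 in one place: isopropylsulfonyl in place of isopropyl on an aromatic carbon.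

Going by the values given here, the only measured step, a 10-fold lower number from compound 1 to compound 2 (1.01 log units; beyond the scatter), concerns an exchange at another position and on another ring of the shared core. Among the compounds with values here, it does not cover an exchange of isopropyl for isopropylsulfonyl, and no other pair among the measured compounds touches that group. Within the data shown here, no measured step therefore bears on the step from compound 3 to compound 4, and the direction and size of the change in this assay cannot be read from the data at hand.

The working expectation is accordingly no step beyond the scatter, with a wide allowance to either side. Compound 4 is estimated at 120000 nM, with a range from 20000 nM to 500000 nM. This estimate means a step of a 1.7-fold lower number from compound 3 to compound 4 (0.24 log units; within the scatter), expected but unsupported by any measured comparison.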

Compound 4, half-maximal inhibitory concentration: 517000 nM
Estimate against measurement, compound 4: 4.3-fold (0.63 log units) below, outside the stated range (above it).
By their numbers in this assay, from the lowest: compound 2; then compound 1; then compound 3; then compound 4.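

In this assay, going by these compounds alone, the exchange of isopropyl for isopropylsulfonyl on the aromatic carbon ortho to an amino group gives a 2.5-fold higher number from compound 3 to compound 4 (0.40 log units; beyond the scatter), the first measured change at this position of the series. The direction is upward: a larger group that brings hydrogen-bond acceptors does not recover the inhibition that was already poor in compound 3, and the number moves further from the lower values seen elsewhere in the series. No measurement of any property of these two groups accompanies the step, so the data offer no explanation for it.

Within the data shown here, with only two groups compared here, the step does not separate the contribution of the sulfonyl unit from that of the added size, and a methyl group, a methylsulfonyl group or a sulfonamide at the same carbon would help to tell these apart. Also open, going by these compounds, is how far the number at this position can fall at all, for instance with a hydrogen, a carboxylic acid, an amine or a longer alkyl chain in place of isopropyl.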